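Compound 1 to compound 4: expected acid dissociation constant

The source may report more compounds than this note shows. Statements on the series, on what has been measured and on what is new or still open speak of the compounds shown alone.

Measured so far (a physicochemical assay)
- compound 1 `O=C1CN(S(=O)(=O)c2cc3ccc(Cl)cc3s2)CCN1Cc1cc2[nH]cccc-2n1` (6.9)
- compound 2 `O=C1CN(S(=O)(=O)c2cc3ccc(Cl)cc3s2)CCN1Cc1cc2cc[nH]cc-2n1` (8)
- compound 3 `O=C1CN(S(=O)(=O)c2cc3ccc(Cl)cc3s2)CCN1Cc1cc2cnccc2o1` (5.8)

Compound 1 stands in the middle of the three (6.9), with compound 2 higher and compound 3 lower. Compound 4 `Nc1[nH]ccc2nc(CN3CCN(S(=O)(=O)c4cc5ccc(Cl)cc5s4)CC3=O)cc1-2` is not yet measured, and its change from compound 1 is a group of 10 heavy atoms (7 carbon, 3 nitrogen; one five-membered aromatic ring with 1 hetero atom, one six-membered aromatic ring with 1 hetero atom) in place of a group of 9 heavy atoms (7 carbon, 2 nitrogen; one five-membered aromatic ring with 1 hetero atom, one six-membered aromatic ring with 1 hetero atom), on a saturated chain carbon bound to an amide-type nitrogen in a ring (the only difference in structure).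

Measured swaps at this place were large, with a number 1.10 log units higher from compound 1 to compound 2 (beyond the scatter) and a number 1.10 log units lower from compound 1 to compound 3 (beyond the scatter) and also a number 2.20 log units lower from compound 2 to compound 3 (beyond the scatter) (all beyond the scatter). None of them adds a heavy atom, so the direction is a judgement. The better guide is compound 2 at 8 rather than compound 3 at 5.8 (its group holds oxygen, which the entering group lacks). A large upward step is expected, estimated as a number 1.60 log units higher from compound 1 to compound 4 (beyond the scatter) in this assay (an expectation only). Compound 4 is estimated at 8.5 (expected range 7.6 to 9.4).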

Compound 4, acid dissociation constant: 9.3
Beside the measured number, compound 4's estimate is 0.80 log units below it, and the stated range covers the measured number.
By their numbers in this assay, from the lowest: compound 3; then compound 1; then compound 2; then compound 4.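

In this assay the group entering in compound 4 gives the highest number of the four, with a number 2.40 log units higher from compound 1 to compound 4 (beyond the scatter), a number 1.30 log units higher from compound 2 to compound 4 (beyond the scatter) and a number 3.50 log units higher from compound 3 to compound 4 (beyond the scatter). Among the compounds shown here, this position, on a saturated chain carbon bound to an amide-type nitrogen in a ring, therefore spans a wider range than the earlier compounds showed, and the group of 10 heavy atoms exceeds all three groups of 9 heavy atoms. No supporting data explain this rise.

Still open, going by these compounds, is how a methoxy group or a carboxylic acid on the same two-ring group would read in this assay. Also open, on these data alone, is whether a longer chain at this carbon would preserve the high number.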